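This account rests on a few compounds, and the source may have more. Where it says the series, first, only, none or still open, it means among the compounds named here.

Measured so far:
compound 1 `COc1cc(C2=C(c3cc(C)c(OC)c(C)c3)C(O)CC2=O)cc(OC)c1OC`, > 100 ug/mL
compound 2 `COc1cc(C2=C(c3cc(C)c(OC)c(C)c3)C(OC(C)=O)CC2=O)cc(OC)c1OC`, > 100 ug/mL
compound 3 `COc1ccc(C2=C(c3cc(OC)c(OC)c(OC)c3)C(=O)C(O)C2)cc1Cl`, < 1 ug/mL

In an ADME assay on HEp-2 cells (Homo sapiens) for cytotoxicity, read by MTT assay, with a stated time of 72 h (a higher number here means a weaker inhibitor, a lower number a stronger inhibitor), compound 1 gives > 100 ug/mL, which is a limit of the assay. Compound 2 also gives > 100 ug/mL, again a limit. The change between them, (acetyl in place of hydrogen on an oxygen on a saturated carbon), therefore gives a step that reads a step that the two limits leave unreadable from compound 1 to compound 2, because of the limit of > 100 ug/mL in this assay, at which 2 of the 3 values shown sit. Compound 3 gives < 1 ug/mL, a limit at the other end, as the limit of < 1 ug/mL in this assay, at which 1 of the 3 values shown sits, shows. The difference between the core of compound 3 and that of compound 1 is not broken down here.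

Compound 4 `COc1ccc(C2=C(c3cc(OC)c(OC)c(OC)c3)C(=O)C(OC(C)=O)C2)cc1Cl` is not yet measured. It differs from compound 3 by acetyl in place of hydrogen on an oxygen on a saturated carbon, the same change as from compound 1 to compound 2. Since that earlier step is unreadable, the expected step that the limit leaves unreadable from compound 3 to compound 4 rests only on compound 3 sitting at < 1 ug/mL. Compound 4 is therefore estimated at 0.7 ug/mL, expected between 0.15 ug/mL and 3 ug/mL.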

Compound 4, half-maximal inhibitory concentration: < 1 ug/mL
Compound 4 was reported as a limit; the forecaster's own chance of this, stated with the estimate: 45%; the middle value lies beyond the limit too.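

Compound 3 and compound 4 are both reported only as limits of the assay, and no step can be read between them. The compounds shown leave open how much the change from hydroxy to acetoxy shifts either core in this assay.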